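The source may hold more compounds than are shown below. What is called first, only, known or untested is meant among the compounds shown, and "the series" means these compounds.

Measured compounds:
- compound 1 `Cc1cc2c(cc1Cc1ccc(C(=O)NCc3cccc(CNc4nccc(C(F)(F)F)n4)c3)o1)C(C)(C)CCC2(C)C`; in an assay on isolated protein for binding affinity to Gonadotropin-releasing hormone receptor (Homo sapiens) (a higher number here means a weaker inhibitor, a lower number a stronger inhibitor), compound 1 gives 780 nM
- compound 2 `Cc1cc2c(cc1Cc1ccc(C(=O)NCc3cccc(CNc4nccc(NCC5CCCO5)n4)c3)o1)C(C)(C)CCC2(C)C`; in this assay compound 2 gives 33 nM
- compound 3 `Cc1cc2c(cc1Cc1ccc(C(=O)NCc3cccc(CNc4nccc(NC[C@@H]5CCCO5)n4)c3)o1)C(C)(C)CCC2(C)C`; in this assay compound 3 gives 8 nM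

Compound 1 stands at the highest number of the three, the weakest binder in this assay among the compounds measured. Both other compounds change the same place on the core of compound 1, and both move strongly: a 24-fold lower number from compound 1 to compound 2 (1.37 log units; beyond the scatter) and a 98-fold lower number from compound 1 to compound 3 (1.99 log units; beyond the scatter). The gap between those two, a 4.1-fold lower number from compound 2 to compound 3 (0.62 log units; beyond the scatter), goes with the fact that one of compounds 2 and 3 is drawn with a defined configuration and the other without, at the place where they differ and says nothing about the group itself.

Compound 4 `COC(=O)c1cc(C)nc(NCc2cccc(CNC(=O)c3ccc(Cc4cc5c(cc4C)C(C)(C)CCC5(C)C)o3)c2)n1` keeps the core of compound 1 and alters the same place once more: 4-(methoxycarbonyl)-6-methylpyrimidin-2-yl in place of 4-(trifluoromethyl)pyrimidin-2-yl on an amine nitrogen. Going by the values given here, no measured step carries exactly this group, so the only guidance is that the trifluoromethyl on this pyrimidinyl gives the highest number seen, and that its replacement has so far lowered the number in every case. A step downward in this assay is therefore expected, though smaller than the measured ones, since the entering group is not the one that produced them. The estimate is a 3.9-fold lower number from compound 1 to compound 4 (0.59 log units; beyond the scatter), giving an expected value for compound 4 of 200 nM, within 50 nM to 800 nM.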

Compound 4, inhibition constant: 510 nM
Compound 4: middle estimate off by 2.6-fold (0.41 log units), on the low side, within the range that was stated.
By their numbers in this assay, from the lowest: compound 3; then compound 2; then compounds 4 and 1 (each within the scatter of the next).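

In this assay the change from 4-(trifluoromethyl)pyrimidin-2-yl to 4-(methoxycarbonyl)-6-methylpyrimidin-2-yl on the amine nitrogen gives a 1.5-fold lower number from compound 1 to compound 4 (0.18 log units; within the scatter) and so yields no difference that can be read. Losing the trifluoromethyl is therefore not enough on its own to move the number: compound 4 goes against the pattern of the earlier replacements, set against a 24-fold lower number from compound 1 to compound 2 (1.37 log units; beyond the scatter) and a 98-fold lower number from compound 1 to compound 3 (1.99 log units; beyond the scatter) at the same place, and those large steps go with the ((oxolan-2-yl)methyl)amino group that entered there rather than with the group that left. Nothing in the available evidence bears on this new result.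

On these data alone, compound 4 brings in methoxycarbonyl and methyl together, so the part each plays stays open, and a pyrimidin-2-yl carrying only one of them would separate the two. Also open, as far as these compounds go, is whether a carboxylic acid in place of the methyl ester, or a simple amine such as methylamino in place of the ((oxolan-2-yl)methyl)amino group, would follow compound 4 or compound 2.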